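Imidazoline series: trifluoromethyl for fluoro on compound 3

This account rests on a few compounds, and the source may have more. Where it says the series, first, only, none or still open, it means among the compounds named here.

Compound 3 `CS(=O)(=O)c1ccc(F)cc1NCC1=NCCN1` gives 16.6 nM in a functional assay for agonist activity at Alpha-1A adrenergic receptor (Homo sapiens) (on this read-out lower numbers stand for an effect already at smaller amounts and higher numbers for an effect only at larger amounts of compound), the highest number among the three measured compounds. Its nearest neighbour is compound 1 `CSc1ccc(F)cc1NCC1=NCCN1`, which gives 2.29 nM; the gap is a 7.2-fold higher number from compound 1 to compound 3 (0.86 log units; beyond the scatter), carrying methylsulfonyl in place of methylsulfanyl on an aromatic carbon. Compound 2 `COc1ccc(SC)c(NCC2=NCCN2)c1` gives 1.59 nM, the furthest of the measured values from compound 3. The step of a 1.4-fold lower number from compound 1 to compound 2 (0.16 log units; within the scatter) carries methoxy in place of fluoro on an aromatic carbon and stays within the scatter.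

Compound 4 `CS(=O)(=O)c1ccc(C(F)(F)F)cc1NCC1=NCCN1` differs from compound 3 by trifluoromethyl in place of fluoro on an aromatic carbon.

For the measured compounds named here, no measured step exchanges fluoro for trifluoromethyl, so the step from compound 3 to compound 4 has no direct precedent in this set. Going by the values given here, the one step that does replace the fluoro, a 1.4-fold lower number from compound 1 to compound 2 (0.16 log units; within the scatter), is within the scatter, which loosely suggests that a replacement there need not move the number much. The step from compound 3 to compound 4 is therefore expected to be small, estimated at a 1.2-fold higher number from compound 3 to compound 4 (0.08 log units; within the scatter), with a wide band to reflect the lack of a matching precedent. Compound 4 is expected to give about 20 nM, within a range of 6 nM to 70 nM.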

Compound 4, half-maximal effective concentration: 1100 nM
Compound 4: the middle estimate sits 55-fold (1.74 log units) below what was measured, and the stated range ends below it.
By their numbers in this assay, from the lowest: compounds 2 and 1 (each within the scatter of the next); then compound 3; then compound 4.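

In this assay, the position para to a methylsulfonyl group proves far from indifferent to what it carries: the step with trifluoromethyl in place of fluoro (a 66-fold higher number from compound 3 to compound 4 (1.82 log units; beyond the scatter)) is large and much exceeds the change from methylsulfanyl to methylsulfonyl (a 7.2-fold higher number from compound 1 to compound 3 (0.86 log units; beyond the scatter)). The only earlier replacement of fluoro at this position (a 1.4-fold lower number from compound 1 to compound 2 (0.16 log units; within the scatter)) lies within the scatter, so tolerance of methoxy alongside methylsulfanyl does not extend to trifluoromethyl alongside methylsulfonyl, although these two steps differ in both the entering group and the group para to it. Nothing shown here offers a measured reason for the size of the new step.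

The compounds shown leave open whether this loss belongs to trifluoromethyl itself or to its combination with methylsulfonyl, and whether it grows gradually with the size of the group or appears only at trifluoromethyl. A methyl, chloro or ethyl group at this position on the core of compound 3, and trifluoromethyl on the methylsulfanyl core of compound 1, would separate these readings.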